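A few compounds are considered here, and "the series" means these few. Any claim that something is new, unique, unknown or untested is made for them only; others in the source may bear on it.

Among the measured compounds shown here, in a functional assay on A2780 cells (Homo sapiens) for antiproliferative activity, read by sulforhodamine B assay, with a stated time of 48 h (a higher number here means a weaker inhibitor of growth, a lower number a stronger inhibitor of growth), compound 1 `CCCCCCC[C@H]1OC(=O)C[C@H]1OC1CCCCC1` gives 16000 nM, while compound 2 `CCCCCCC[C@H]1OC(=O)C[C@H]1OCc1ccccc1` gives 63000 nM, the higher of the two numbers so far. Compound 3 `C=CCC(C)O[C@@H]1CC(=O)O[C@@H]1CCCCCCC` is unmeasured and differs from compound 2 by 1-methylbut-3-en-1-yl in place of benzyl on an oxygen on a saturated carbon, with 1-methylbut-3-en-1-yl in place of benzyl on an oxygen on a saturated carbon. For the measured compounds named here, the one measured step that bears on this is a 3.9-fold higher number from compound 1 to compound 2 (0.60 log units; beyond the scatter), with benzyl in place of cyclohexyl. Compound 1, at 16000 nM, also has no aromatic ring on that oxygen, so a modest move to a lower number is expected in this assay. The expected step is a 2.3-fold lower number from compound 2 to compound 3 (0.35 log units; beyond the scatter). For compound 3 the estimated value is 28000 nM, with an expected range of 11000 nM to 65000 nM.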

Compound 3, concentration for 50% growth inhibition: 48000 nM
For compound 3 the middle estimate is 1.7-fold (0.23 log units) below the measured one; the range from low to high includes it.
By their numbers in this assay, from the lowest: compound 1; then compounds 3 and 2 (each within the scatter of the next).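

In this assay, replacing benzyl with the open-chain 1-methylbut-3-en-1-yl on this oxygen (a 1.3-fold lower number from compound 2 to compound 3 (0.12 log units; within the scatter)) shows that removing the aromatic ring here gives no change beyond the scatter. Compound 1 with its cyclohexyl group still stands apart from the new group (a 3.0-fold higher number from compound 1 to compound 3 (0.48 log units; beyond the scatter)), so lacking an aromatic ring does not by itself bring the number down to that of compound 1. Nothing measured here explains these differences.

Open, going by these compounds, is how an amine or a carboxylic acid on this oxygen would read in this assay. Also open, on these data alone, is whether a smaller ring such as cyclopentyl would match cyclohexyl.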